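The source may hold more compounds than are shown below. What is called first, only, known or untested is meant among the compounds shown, and "the series" means these compounds.

Values in a toxicity assay on NIH3T3 cells (Mus musculus) for cytotoxicity, read by resazurin assay (on this read-out lower numbers stand for an effect already at smaller amounts and higher numbers for an effect only at larger amounts of compound), follow.

Compound 1 `COC(=O)c1ccc(NCc2cncn2Cc2ccc(N)cc2)cc1-c1ccccc1` gives > 10000 nM as a limit.
Compound 2 `COC(=O)c1ccc(NCc2cncn2Cc2ccccc2Cl)cc1-c1ccccc1` gives 10000 nM as a number.
Compound 3 `COC(=O)c1ccc(NCc2cncn2Cc2ccc([N+](=O)[O-])cc2)cc1-c1ccccc1` gives > 10000 nM as a limit.

Compound 3 therefore stands at the limit of > 10000 nM in this assay, at which 2 of the 3 values shown sit, with no number of its own. The change to compound 4 `COC(=O)c1ccc(NCc2cncn2Cc2ccccc2Br)cc1-c1ccccc1` is 2-bromophenyl in place of 4-nitrophenyl on a saturated chain carbon bound to an aromatic nitrogen in one place: 2-bromophenyl in place of 4-nitrophenyl on a saturated chain carbon bound to an aromatic nitrogen. Going by these compounds, the nearest measured step is a number no lower from compound 2 to compound 3 (the limit leaves the size open) and its size stays open, as does that of a number no higher from compound 1 to compound 2 (the limit leaves the size open) here. Going by the values given here, compound 2, with its 2-chlorophenyl, gives 10000 nM as the only number available. The expected step is a number no higher from compound 3 to compound 4 (the limit leaves the size open) in this assay with no shift beyond the scatter. For compound 4 the estimate is 10000 nM with an expected range from 4000 nM to 20000 nM and a fair chance of another limit.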

Compound 4, half-maximal effective concentration: 10000 nM
Compound 4: the middle estimate sits on the measured number at the digits printed, and the stated range covers the measured number.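

With bromo in place of chloro on an aromatic carbon, this assay shows no change at the digits printed from compound 2 to compound 4 (within the scatter). This is the first step among these compounds whose size can be read, and it leaves the read-out in place for this exchange of one halogen for another. The other steps to compound 4 cannot be read, because compound 1 and compound 3 stand at a limit: the limit of > 10000 nM in this assay, at which 2 of the 4 values shown sit.

Beyond that, this assay shows only a number no higher from compound 3 to compound 4 (the limit leaves the size open) and a number no higher from compound 1 to compound 4 (the limit leaves the size open), and the compounds shown leave open whether fluoro or methyl in place of the bromo would give a number beyond the scatter from that of compound 4.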